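Chloro in place of hydrogen: compound 2 to compound 3

This account rests on a few compounds, and the source may have more. Where it says the series, first, only, none or still open, it means among the compounds named here.

Values in a functional assay on MCF7 cells (Homo sapiens); a lower number here means a stronger inhibitor of growth, a higher number a weaker inhibitor of growth:
- Compound 1 `O=S(=O)(/C=C/c1ccc(Cl)c(Cl)c1)Cc1ccc(Nc2ncnc3ccccc23)cc1`: 28000 nM
- Compound 2 `O=S(=O)(/C=C/c1ccc(Cl)cc1)Cc1ccc(Nc2ncnc3ccccc23)cc1`: 52000 nM
- Compound 3 `O=S(=O)(/C=C/c1ccc(Cl)cc1Cl)Cc1ccc(Nc2ncnc3ccccc23)cc1`: not yet measured

Compound 2, at 52000 nM, lies within the scatter of compound 1, so the pair gives it no separate rank. Compound 3 follows from compound 2 by chloro in place of hydrogen on an aromatic carbon, ortho to a large group and meta to a chloro group, turning 4-chlorophenyl into 2,4-dichlorophenyl: chloro in place of hydrogen on an aromatic carbon. For the measured compounds named here, the one measured step that bears on this is a 1.9-fold higher number from compound 1 to compound 2 (0.27 log units; within the scatter), the reverse kind of change, and it lies within the scatter. It involves a different chloro, and the chloro entering here has no measurement of its own. On that evidence, no change beyond the scatter is expected in this assay. The expected step is a 1.5-fold lower number from compound 2 to compound 3 (0.17 log units; within the scatter). The estimate for compound 3 is 35000 nM, with an expected range of 15000 nM to 80000 nM.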

Compound 3, concentration for 50% growth inhibition: 4000 nM
Beside the measured number, compound 3's estimate is 8.8-fold (0.94 log units) above it, outside the stated range (below it).
By their numbers in this assay, from the lowest: compound 3; then compounds 1 and 2 (each within the scatter of the next).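

In this assay, the position ortho to a large group proves sensitive: chloro in place of hydrogen there gives a 13-fold lower number from compound 2 to compound 3 (1.11 log units; beyond the scatter), a step beyond the scatter, whereas the earlier change at a different place gave only a 1.9-fold higher number from compound 1 to compound 2 (0.27 log units; within the scatter), which lies within it. Having two chloro groups is therefore not enough in itself, since 2,4-dichlorophenyl in place of 3,4-dichlorophenyl gives a 7.0-fold lower number from compound 1 to compound 3 (0.85 log units; beyond the scatter), and the arrangement on the ring matters in this pair. Nothing available gives a reason for this gain.

Going by these compounds, it remains open whether the gain belongs to chloro specifically or would also appear with fluoro, methyl or methoxy at this place. Also open, on these data alone, is whether 2-chlorophenyl alone would keep the gain, or whether it depends on both chloro groups of 2,4-dichlorophenyl.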